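The source may report more compounds than this note shows. Statements on the series, on what has been measured and on what is new or still open speak of the compounds shown alone.

Working notes on the series. Compound 1 `Cc1ccc(OCc2nnc(C(=O)Nc3ccc(CCC(=O)O)cc3)s2)cc1C` gives 1130 nM in a functional assay on CHO cells for agonist activity at Free fatty acid receptor 1 (Homo sapiens), read by FLIPR and calcium flux, tested at 1 uM; on this read-out higher numbers stand for an effect only at larger amounts of compound and lower numbers for an effect already at smaller amounts. Compound 2 `O=C(O)CCc1ccc(NC(=O)c2nnc(COc3cccc(C(F)(F)F)c3)s2)cc1` gives 3090 nM in this assay, and compound 3 `Cc1cccc(OCc2nnc(C(=O)Nc3ccc(CCC(=O)O)cc3)s2)c1` gives 3260 nM. Compound 3 therefore carries the highest of the three numbers: against compound 2 the gap is a 1.1-fold higher number from compound 2 to compound 3 (0.02 log units; within the scatter), against compound 1 it is a 2.9-fold higher number from compound 1 to compound 3 (0.46 log units; beyond the scatter), so only the distance to compound 1 is beyond the scatter.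

Compound 4 `COc1ccc(OCc2nnc(C(=O)Nc3ccc(CCC(=O)O)cc3)s2)cc1` is the next member. Relative to compound 3 the change is 4-methoxyphenyl in place of 3-methylphenyl on an oxygen on a saturated carbon, so the methyl leaves the 3-position and a methoxy enters at the 4-position of the aryl ring on the ether oxygen.

Among the measured compounds shown here, the steps that bear on this: a 2.9-fold higher number from compound 1 to compound 3 (0.46 log units; beyond the scatter) shows that removing a methyl from the 4-position of the aryl group costs potency; a 2.7-fold higher number from compound 1 to compound 2 (0.44 log units; beyond the scatter) shows a comparable loss on exchanging the whole aryl group; a 1.1-fold higher number from compound 2 to compound 3 (0.02 log units; within the scatter) shows that 3-methyl and 3-trifluoromethyl read alike. Occupying the 4-position is thus the only change with a measurable effect so far, and a methoxy there is expected to read somewhat lower than compound 3, but not beyond the scatter. For compound 4 in this assay the expected value is 2200 nM, with a range from 800 nM to 6000 nM, i.e. an expected step of a 1.5-fold lower number from compound 3 to compound 4 (0.17 log units; within the scatter).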

Compound 4, half-maximal effective concentration: 2430 nM
Compound 4: the middle estimate sits 1.1-fold (0.04 log units) below what was measured; measured number inside the range.
By their numbers in this assay, from the lowest: compound 1; then compounds 4, 2 and 3 (each within the scatter of the next).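

In this assay, the 4-methoxyphenyl group does not separate from 3-methylphenyl (a 1.3-fold lower number from compound 3 to compound 4 (0.13 log units; within the scatter)) or from 3-(trifluoromethyl)phenyl (a 1.3-fold lower number from compound 2 to compound 4 (0.10 log units; within the scatter)), so moving to a single methoxy substituent on this aryl ring gives no readable change against either single-substituent analogue. Against 3,4-dimethylphenyl the step remains beyond the scatter (a 2.2-fold higher number from compound 1 to compound 4 (0.33 log units; beyond the scatter)), which shows that a 4-substituent alone, at least as methoxy, does not reproduce the number of compound 1, and 3,4-dimethylphenyl is the only aryl group here that stands apart from the other three. No measured evidence accounts for this difference in the read-out.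

Still open, from the compounds shown here alone, is whether a 4-methylphenyl group on the same oxygen would read with compound 1 or with compounds 2, 3 and 4, so the share of each methyl in compound 1 cannot yet be separated. Also open, going by these compounds, is how a 3,4-dimethoxyphenyl group, or an aryl group carrying an amine, would read in this place.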